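The source may hold more compounds than are shown below. What is called first, only, known or untested is meant among the compounds shown, and "the series" means these compounds.

Measured so far in a functional assay on HeLa cells (Homo sapiens) for antiproliferative activity, read by MTT assay, with a stated time of 72 h; on this read-out lower numbers stand for stronger inhibition and higher numbers for weaker inhibition:
- compound 1 `CC/C=C/C(=O)Nc1cccc(Oc2nc(Nc3cccc(OC)c3)nc3c2CSCC3)c1` gives 27200 nM
- compound 2 `COc1cccc(Nc2nc3c(c(Oc4cccc(NC(=O)C=C(C)C)c4)n2)CSCC3)c1` gives 19100 nM

Going by the values given here, the only measured step is a 1.4-fold lower number from compound 1 to compound 2 (0.15 log units; within the scatter) with 2-methylprop-1-en-1-yl in place of but-1-en-1-yl on a carbonyl carbon. Among the compounds with values here, compound 1 therefore stands level with its single measured neighbour, with no order between the two.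

Compound 3 `CC/C=C/C(=O)Nc1cccc(Oc2nc(Nc3cccc(C#N)c3)nc3c2CSCC3)c1` departs from compound 1 by cyano in place of methoxy on an aromatic carbon with cyano in place of methoxy on an aromatic carbon, meta to a large group. Within the data shown here, the one measured step lies at a different place, and no measured pair covers this change. It offers only a weak guide to size and none to direction, so no step beyond the scatter is expected in this assay here. The expected step is a 1.2-fold lower number from compound 1 to compound 3 (0.09 log units; within the scatter) with the direction left open. Compound 3 is estimated at 22000 nM within an expected range from 8000 nM to 55000 nM for now.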

Compound 3, half-maximal inhibitory concentration: 31800 nM
For compound 3 the middle estimate is 1.4-fold (0.16 log units) below the measured one, and the stated range covers the measured number.
By their numbers in this assay, from the lowest: compounds 2, 1 and 3 (each within the scatter of the next).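

In this assay, going by these compounds alone, the first reading at this position is a 1.2-fold higher number from compound 1 to compound 3 (0.07 log units; within the scatter), for (3-cyanophenyl)amino in place of (3-methoxyphenyl)amino. Cyano and methoxy therefore cannot be told apart on this aromatic carbon, so a second place in the series, besides the carbonyl end, now shows a single change that stays within the scatter. The data give no reason for this result.

As far as these compounds go, it remains open whether a different group on this carbon, such as an amine, a carboxylic acid or a longer alkoxy chain, would move the number beyond the scatter. From the compounds shown here alone, it is also open whether cyano in place of methoxy reads the same when the 2-methylprop-1-en-1-yl amide of compound 2 is present.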